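Compound 3 to compound 4: saturating the hydroxyl-ended chain

The compounds below may be only part of what the source reports. "The series", "measured", "known", "first", "only" and "open" are said of these compounds alone.

Values in a functional assay on SW1573 cells (Homo sapiens) for antiproliferative activity, read by sulforhodamine B assay, with a stated time of 48 h; a lower number here means a stronger inhibitor of growth, a higher number a weaker inhibitor of growth:
- Compound 1 `C=CCOC[C@H]1OCCC[C@H]1O[Si](C)(C)C(C)(C)C`: 18000 nM
- Compound 2 `COC(=O)/C=C/OC[C@H]1OCCC[C@H]1O[Si](C)(C)C(C)(C)C`: 50000 nM
- Compound 3 `CC(C)(C)[Si](C)(C)O[C@@H]1CCCO[C@@H]1CO/C=C/CO`: > 100000 nM

Compound 3 gives > 100000 nM, which is a limit and not a number, and it stands at the limit of > 100000 nM in this assay, at which 1 of the 3 values shown sits.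

Compound 4 `CC(C)(C)[Si](C)(C)O[C@@H]1CCCO[C@@H]1COCCCO` keeps the core of compound 3 and carries 3-hydroxypropyl in place of 3-hydroxyprop-1-en-1-yl on an oxygen on a saturated carbon.

For the measured compounds named here, no measured step makes this exact change. The nearest evidence is the pair of steps that reach the hydroxyl-ended chain: an at least 5.5-fold higher number from compound 1 to compound 3 (0.74 log units; beyond the scatter), and an at least 2.0-fold higher number from compound 2 to compound 3 (0.30 log units; that floor lies within the scatter). Both show weak growth inhibition with that chain, although the floor of the second does not clear the scatter. Compound 4 keeps the terminal hydroxyl of compound 3, so no step beyond the scatter is expected in this assay, and a further report at the limit is quite possible.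

The expected step is a number no higher from compound 3 to compound 4 (the limit leaves the size open).

For compound 4 the estimated value is 100000 nM, with an expected range of 45000 nM to 200000 nM.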

Compound 4, concentration for 50% growth inhibition: > 100000 nM
Compound 4: a limit, no number; the forecaster's own chance of this, stated with the estimate: 60%; the middle value lies on the limit itself.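

In this assay compound 4 gives > 100000 nM, which is a limit of the assay and not a number. For the compounds shown here, the readable steps are an at least 5.5-fold higher number from compound 1 to compound 4 (0.74 log units; beyond the scatter) and an at least 2.0-fold higher number from compound 2 to compound 4 (0.30 log units; that floor lies within the scatter), so only the step from the allyl ether clears the scatter. The step from compound 3 cannot be read, as both ends are limits, but a hydroxyl-ended chain now stays at the limit both with the double bond of 3-hydroxyprop-1-en-1-yl and with the saturated 3-hydroxypropyl: the limit of > 100000 nM in this assay, at which 2 of the 4 values shown sit.

On these data alone, whether the double bond matters at all remains open, since neither hydroxyl-ended compound gives a number. Also open, as far as these compounds go, is whether a different chain end on this oxygen, such as a primary amine, a carboxylic acid or a longer chain ending in hydroxyl, would bring a measurable value.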